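The compounds below may be only part of what the source reports. "The series", "measured", "known", "first", "only" and "open" are said of these compounds alone.

Measured so far:
Compound 1, `COc1cccc(CNCCCNc2ccnc3cc(-c4ccccc4)ccc23)c1O`, in an ADME assay for permeability, using PAMPA, with a stated time of 30 min, at pH 7.4 (a lower number here means that the compound crosses the layer more slowly, a higher number that the compound crosses the layer faster), gives 237 10^-6 cm/s.
Compound 2, `COc1cccc(CNCCCNc2ccnc3cc(Cc4ccc(F)cc4)ccc23)c1O`, gives 23 10^-6 cm/s.
Compound 3, `COc1cccc(CNCCCNc2ccnc3cc(Oc4cccc(N(C)C)c4)ccc23)c1O`, gives 317 10^-6 cm/s.

Compound 3 thus holds the highest of the three numbers, though the step of a 1.3-fold higher number from compound 1 to compound 3 (0.13 log units; within the scatter) stays within the scatter, while the step of a 14-fold higher number from compound 2 to compound 3 (1.14 log units; beyond the scatter) is large. Compound 4, `COc1ccccc1Oc1ccc2c(NCCCNCc3cccc(OC)c3O)ccnc2c1`, differs from compound 3 by 2-methoxyphenyl in place of 3-(dimethylamino)phenyl on an oxygen on an aromatic ring. Among the measured compounds shown here, no measured step swaps one substituted phenyl for another on this oxygen; the step of a 1.3-fold higher number from compound 1 to compound 3 (0.13 log units; within the scatter) shows that introducing the aryl ether itself left the number where it was, whereas a 10-fold lower number from compound 1 to compound 2 (1.01 log units; beyond the scatter) concerns a different kind of change. A step of a 1.1-fold lower number from compound 3 to compound 4 (0.05 log units; within the scatter) is therefore expected, essentially none beyond the scatter. Compound 4 is estimated at 280 10^-6 cm/s, within 140 10^-6 cm/s to 560 10^-6 cm/s.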

Compound 4, apparent permeability: 317 10^-6 cm/s
The estimate for compound 4 lay 1.1-fold (0.05 log units) below the measured number; measured number inside the range.
By their numbers in this assay, from the lowest: compound 2; then compounds 1, 3 and 4 (each within the scatter of the next).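

In this assay, among the compounds shown here, this is the first swap of one substituted phenyl for another on this oxygen, and it gives no change at the digits printed from compound 3 to compound 4 (within the scatter), so 2-methoxyphenyl and 3-(dimethylamino)phenyl cannot be told apart here. Against the other two compounds, 2-methoxyphenoxy matches what 3-(dimethylamino)phenoxy showed, with a 1.3-fold higher number from compound 1 to compound 4 (0.13 log units; within the scatter) and a 14-fold higher number from compound 2 to compound 4 (1.14 log units; beyond the scatter). Nothing available offers an explanation for these numbers.

Only two substituted phenyls are compared on this oxygen. Going by these compounds, whether a phenyl carrying a carboxylic acid, or a simple ethyl group in place of the phenyl, would keep the number this high remains open.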